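The compounds below may be only part of what the source reports. "The series", "measured", "known", "first", "only" and "open" are said of these compounds alone.

Measured compounds:
compound 1 `Cc1cn([C@@H]2O[C@H](CO[Si](C)(C)C(C)(C)C)[C@@]3(OS(=O)(=O)C=C3NCC(=O)O)[C@H]2O[Si](C)(C)C(C)(C)C)c(=O)n(C)c1=O` — 300000 nM
compound 2 `COC(=O)CC(=O)NC1=CS(=O)(=O)O[C@@]12[C@@H](CO[Si](C)(C)C(C)(C)C)O[C@@H](n1cc(C)c(=O)n(C)c1=O)[C@@H]2O[Si](C)(C)C(C)(C)C` — 400000 nM

Both were tested in a functional assay on HEL cells (Homo sapiens) for cytotoxicity, read by microscopy; a higher number here means that more compound is tolerated, a lower number that less compound is tolerated. Compound 1 gives 300000 nM and compound 2 gives 400000 nM, so compound 2 holds the higher of the two numbers, but a 1.3-fold higher number from compound 1 to compound 2 (0.12 log units; within the scatter) lies within the scatter, and no order between the two compounds can be claimed from it.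

Compound 3 `Cc1cn([C@@H]2O[C@H](CO[Si](C)(C)C(C)(C)C)[C@@]3(OS(=O)(=O)C=C3NCCC(=O)O)[C@H]2O[Si](C)(C)C(C)(C)C)c(=O)n(C)c1=O` has not been measured in this assay. It differs from compound 2 in one place: 2-carboxyethyl in place of ((methoxycarbonyl)methyl)carbonyl on an amine nitrogen. For the measured compounds named here, the single measured step bears directly on this position: it exchanged carboxymethyl for ((methoxycarbonyl)methyl)carbonyl on the same amine nitrogen and gave a 1.3-fold higher number from compound 1 to compound 2 (0.12 log units; within the scatter), within the scatter. Compound 3 carries a 2-carboxyethyl chain on that nitrogen, which is closer to the carboxymethyl of compound 1 than to the acyl group of compound 2. Both measured compounds already sit at the high end of this read-out, so the return from an acyl group to an acid chain is expected to move the number little; a 1.1-fold lower number from compound 2 to compound 3 (0.06 log units; within the scatter) is the step expected. Compound 3 is estimated at 350000 nM in this assay, with a range of 150000 nM to 800000 nM.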

Compound 3, minimum cytotoxic concentration: 80000 nM
The estimate for compound 3 lay 4.4-fold (0.64 log units) above the measured number, outside the stated range (below it).
By their numbers in this assay, from the lowest: compound 3; then compounds 1 and 2 (each within the scatter of the next).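

In this assay this amine nitrogen does respond to its substituent: the exchange of carboxymethyl for ((methoxycarbonyl)methyl)carbonyl stayed within the scatter, but 2-carboxyethyl in place of ((methoxycarbonyl)methyl)carbonyl gives a 5.0-fold lower number from compound 2 to compound 3 (0.70 log units; beyond the scatter), so less compound is tolerated. With the terminal carboxylic acid kept, lengthening the chain from carboxymethyl to 2-carboxyethyl gives a 3.8-fold lower number from compound 1 to compound 3 (0.57 log units; beyond the scatter), which shows that the acid alone does not fix the number and that chain length on this nitrogen matters in these compounds. Nothing available accounts for this shift.

For the compounds shown here, two acid chain lengths give only one comparison, so whether a longer chain, such as 3-carboxypropyl, would lower the number further remains open. Also open, on these data alone, is whether the lower number of compound 3 depends on the free carboxylic acid, which the methyl ester or primary amide of the 2-carboxyethyl chain would test, or on the chain itself, which a plain propyl group or a terminal amine would test.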